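A few compounds are considered here, and "the series" means these few. Any claim that something is new, unique, unknown or untested is made for them only; others in the source may bear on it.

Of the compounds shown here, three built on one shared core have been measured in an assay on HEK293 cells for displacement of a labelled ligand from 5-hydroxytryptamine receptor 6 (Homo sapiens), read by scintillation counting, with a stated time of 1 h; on this read-out higher numbers stand for weaker inhibition and lower numbers for stronger inhibition. Compound 1 `Cc1[nH]c2ccc(F)cc2c1C1=CCNCC1` gives 30 nM. Compound 2 `Cc1[nH]c2ccccc2c1C1=CCNCC1` gives 200 nM. Compound 3 `CSc1ccc2[nH]c(C)c(C3=CCNCC3)c2c1` gives 20 nM, the lowest of the three numbers; its nearest neighbour is compound 1, within the usual scatter, and its furthest is compound 2, where the gap is a 10-fold lower number from compound 2 to compound 3 (1.00 log units; beyond the scatter).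

Compound 4 `Cc1[nH]c2ccc([N+](=O)[O-])cc2c1C1=CCNCC1` has not yet been measured. It differs from compound 3 in one place: nitro in place of methylsulfanyl on an aromatic carbon. Going by the values given here, no measured step exchanges a nitro group, so guidance is indirect. The step of a 10-fold lower number from compound 2 to compound 3 (1.00 log units; beyond the scatter) shows that a group on this carbon, rather than hydrogen, gives a clearly lower number; the step of a 1.5-fold lower number from compound 1 to compound 3 (0.18 log units; within the scatter) shows that fluoro and methylsulfanyl lie within the scatter of each other, and the step of a 6.7-fold higher number from compound 1 to compound 2 (0.82 log units; beyond the scatter) points the same way. Compound 4 is therefore expected to stay close to compounds 1 and 3. The expected step is a 2.0-fold higher number from compound 3 to compound 4 (0.30 log units; within the scatter), small. Compound 4 is estimated at 40 nM, between 10 nM and 160 nM.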

Compound 4, half-maximal inhibitory concentration: 10 nM
Compound 4: middle estimate off by 4.0-fold (0.60 log units), on the high side; the measured number falls inside the stated range.
By their numbers in this assay, from the lowest: compounds 4, 3 and 1 (each within the scatter of the next, the first and the last beyond it); then compound 2.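

In this assay, nitro is a third group on this aromatic carbon that gives a clearly lower number than hydrogen, and this step is large (a 20-fold lower number from compound 2 to compound 4 (1.30 log units; beyond the scatter)). Going by these compounds alone, it also shows for the first time that two groups on this carbon can differ beyond the scatter (a 3.0-fold lower number from compound 1 to compound 4 (0.48 log units; beyond the scatter)), whereas fluoro and methylsulfanyl stayed within the scatter of each other. Nitro and methylsulfanyl cannot be told apart (a 2.0-fold lower number from compound 3 to compound 4 (0.30 log units; within the scatter)), and nothing available here explains how any of these groups acts on the number.

The compounds shown leave open how an amine, a carboxylic acid or a longer chain such as butyl would behave on this carbon. They also leave open whether nitro would give a similar number on another carbon of the same ring.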